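Dropping the chloro from compound 3

The compounds below may be only part of what the source reports. "The series", "measured", "known", "first", "only" and "open" are said of these compounds alone.

In a functional assay on NB1 cells (Homo sapiens) for antiproliferative activity, with a stated time of 72 h (a lower number here means a stronger inhibitor, a higher number a weaker inhibitor), compound 3 `CN(C)c1ccc(C(=O)N(CCC(=O)NCc2ccc(Cl)cc2)Cc2ccc(C(=O)NO)cc2)cc1` gives 850 nM as the lowest of three values, with compound 1 `O=C(CCN(Cc1ccc(C(=O)NO)cc1)C(=O)c1ccccc1)NCc1ccccc1` at 6660 nM and compound 2 `COc1cc(OC)cc(C(=O)N(CCC(=O)NCc2ccccc2)Cc2ccc(C(=O)NO)cc2)c1` at 13300 nM as the higher numbers. Compound 4 `CN(C)c1ccc(C(=O)N(CCC(=O)NCc2ccccc2)Cc2ccc(C(=O)NO)cc2)cc1` has hydrogen in place of chloro on an aromatic carbon, so 4-chlorobenzyl becomes benzyl (hydrogen in place of chloro on an aromatic carbon). Going by the values given here, the one measured step is a 2.0-fold higher number from compound 1 to compound 2 (0.30 log units; within the scatter) and concerns another group, so it sets no size here. Among the compounds with values here, no measured pair isolates the chloro. Compound 1 also carries benzyl and gives 6660 nM but differs from compound 4 at the carbonyl as well, which leaves the size uncertain. The expected step is a 2.9-fold higher number from compound 3 to compound 4 (0.47 log units; beyond the scatter) towards a higher number. Estimated for compound 4 is 2500 nM with an expected range of 800 nM to 7000 nM for repeat measurements.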

Compound 4, half-maximal inhibitory concentration: 1720 nM
Estimate against measurement, compound 4: 1.5-fold (0.16 log units) above; measured number inside the range.
By their numbers in this assay, from the lowest: compound 3; then compound 4; then compounds 1 and 2 (each within the scatter of the next).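

In this assay, the chloro of the 4-chlorobenzyl group makes a modest difference, with a 2.0-fold higher number from compound 3 to compound 4 (0.31 log units; beyond the scatter). With benzyl held constant, dimethylamino in place of hydrogen gives a 3.9-fold lower number from compound 1 to compound 4 (0.59 log units; beyond the scatter), and 4-(dimethylamino)phenyl in place of 3,5-dimethoxyphenyl gives a 7.7-fold lower number from compound 2 to compound 4 (0.89 log units; beyond the scatter). Compound 4 therefore keeps a lower number than compounds 1 and 2 without the chloro, so that lower number does not depend on it.

Going by these compounds, whether fluoro, bromo or methyl in place of the chloro would give a similar number remains open. No measurement here explains these steps.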